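Compound 3 to compound 4: a ring-free side chain

The source may report more compounds than this note shows. Statements on the series, on what has been measured and on what is new or still open speak of the compounds shown alone.

In a physicochemical assay for lipophilicity, read by HPLC, at pH 7.5 (a higher number here means a more lipophilic compound, a lower number a more polar compound), compound 1 (`CCOc1ccccc1-c1ccc(-c2nc3cnccc3c(NC(C)C(=O)O)c2C#N)cc1`) gives 2.1 and compound 2 (`CCOc1ccccc1-c1ccc(-c2nc3cnccc3c(C[C@H](C)C(=O)O)c2C#N)cc1`) gives 2.2. The step between them is a number 0.10 log units higher from compound 1 to compound 2 (within the scatter). Compound 3 (`CCOc1ccccc1-c1ccc(-c2nc3cnccc3c(NC(C(N)=O)C3CC3)c2C#N)cc1`) stands highest of the three at 3.

Compound 4 (`CCOc1ccccc1-c1ccc(-c2nc3cnccc3c(N[C@H](CC(C)C)C(N)=O)c2C#N)cc1`) differs from compound 3 in one place: a group of 8 heavy atoms (6 carbon, 1 nitrogen, 1 oxygen; no ring) in place of a group of 7 heavy atoms (5 carbon, 1 nitrogen, 1 oxygen; one three-membered non-aromatic ring of carbon only), on a nitrogen on an aromatic ring. The group that leaves holds a three-membered non-aromatic ring of carbon only. The group that enters is 1-carbamoyl-3-methylbutyl, which has no ring and one defined stereocentre.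

Among the measured compounds shown here, no measured step makes this exact exchange. The nearest evidence is a number 0.90 log units higher from compound 1 to compound 3 (beyond the scatter) and a number 0.80 log units higher from compound 2 to compound 3 (beyond the scatter). Both of those steps also remove a carboxy group, which the change to compound 4 does not do, so they serve only as a loose upper guide. The step between compound 1 and compound 2 alters a different part of the side chain and offers little here.

A smaller rise than those two steps is therefore expected, and the expected step in this assay is a number 0.40 log units higher from compound 3 to compound 4 (beyond the scatter). For compound 4 the estimated value is 3.4, with an expected range from 3 to 3.9.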

Compound 4, distribution coefficient: 3.4
For compound 4 middle estimate and measured number coincide at the digits printed; measured number inside the range.
By their numbers in this assay, from the lowest: compounds 1 and 2 (each within the scatter of the next); then compound 3; then compound 4.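

At the place on a nitrogen on an aromatic ring, this assay responds to a change within the carbamoyl-bearing side chains, not only to the exchange of a carboxy-bearing group: replacing the group with the three-membered ring by the ring-free 1-carbamoyl-3-methylbutyl gives a number 0.40 log units higher from compound 3 to compound 4 (beyond the scatter). Measured against the carboxy-bearing compounds, the same side chain gives a number 1.30 log units higher from compound 1 to compound 4 (beyond the scatter) and a number 1.20 log units higher from compound 2 to compound 4 (beyond the scatter), both larger than any step among compounds 1 to 3, and the first of these is a change on the same nitrogen. No measurement on hand bears on the origin of these steps.

Compound 4 differs from compound 3 at once in the loss of the ring, in the carbon count of the group and in a defined stereocentre, so the part each plays in the step stays unresolved. Also open, going by these compounds, is how this assay would read with a cyclobutyl or cyclohexyl ring in the side chain, with a straight butyl chain in place of the branched one, with the opposite stereocentre, or with an amine in place of the carbamoyl.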